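A few compounds are considered here, and "the series" means these few. Any claim that something is new, unique, unknown or untested is made for them only; others in the source may bear on it.

Measured so far:
- compound 1 `CCc1nc2c(-c3ccc(Cl)cc3Cl)ccnc2n1C(CCOC)C1CCC1`: 2.4 nM
- compound 2 `CCC(CCOC)n1c(C2CC2)nc2c(-c3ccc(C(F)(F)F)cc3Cl)ccnc21`: 20.8 nM
- compound 3 `CCc1nc2c(-c3ccc(C(F)(F)F)cc3Cl)ccnc2n1C(CC)COC`: 4.7 nM

These values come from an assay for binding affinity to Corticotropin releasing factor receptor (Rattus norvegicus); on this read-out higher numbers stand for weaker inhibition and lower numbers for stronger inhibition. Compound 1 has the lowest number of the three. Its gap to compound 3 lies within the usual scatter of this assay, so the two cannot be told apart, while its gap to compound 2 lies beyond the scatter.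

Compound 4 `CCc1nc2c(-c3ccc(Cl)cc3Cl)ccnc2n1[C@H](CC)C1CC1` has not yet been measured. It differs from compound 1 in one place: 1-cyclopropylpropyl in place of 1-cyclobutyl-3-methoxypropyl on an aromatic nitrogen. Among the measured compounds shown here, no pair of measured compounds shows this particular change, so its effect is unknown. The expectation is a step of a 1.5-fold higher number from compound 1 to compound 4 (0.16 log units; within the scatter), that is, no change beyond the scatter in either direction. Compound 4 is therefore estimated at 3.5 nM, with a likely range from 1.2 nM to 10 nM.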

Compound 4, inhibition constant: 0.2 nM
Compound 4: the middle estimate sits 18-fold (1.24 log units) above what was measured; the measured number lies below the stated range.
By their numbers in this assay, from the lowest: compound 4; then compounds 1 and 3 (each within the scatter of the next); then compound 2.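

In this assay the change on this aromatic nitrogen brings a 12-fold lower number from compound 1 to compound 4 (1.08 log units; beyond the scatter) and so shows that this position strongly affects the read-out. The methoxy oxygen and the larger 1-cyclobutyl-3-methoxypropyl group are not needed for a low number, since the smaller 1-cyclopropylpropyl, which has no hydrogen-bond acceptor, does better. No evidence here explains the size of this step.

On these data alone, the ring, the chain and the oxygen all change at once, so the contribution of each stays open. Also open, as far as these compounds go, are the opposite stereocentre of 1-cyclopropylpropyl and whether an amine on this chain would be tolerated.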